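Indole series: primary amine on the side chain

This account rests on a few compounds, and the source may have more. Where it says the series, first, only, none or still open, it means among the compounds named here.

Measured so far:
compound 1 `CCCc1c[nH]c2ccc(F)cc12` — > 100 nM
compound 2 `NCCCCc1c[nH]c2c(F)cccc12` — 21 nM

In an assay on isolated protein for inhibition of Myeloperoxidase (Homo sapiens), read by ELISA, with a stated time of 5 min (on this read-out lower numbers stand for stronger inhibition and higher numbers for weaker inhibition), compound 1 gives only a limit, > 100 nM (the limit of > 100 nM in this assay, at which 1 of the 2 values shown sits). Compound 2, whose side chain ends in a primary amine, gives 21 nM in this assay. Compound 3 `NCCSCCc1c[nH]c2ccc(F)cc12` is not yet measured; it differs from compound 1 by (2-aminoethyl)sulfanyl in place of methyl on a saturated chain carbon, two bonds along the chain from an aromatic carbon. Within the data shown here, no step between measured compounds is available, so the expectation rests on compound 2 giving 21 nM with an amine-terminated chain: a gain in this assay beyond the scatter is expected, an at least 2.5-fold lower number from compound 1 to compound 3 (0.39 log units; beyond the scatter). Compound 3 is estimated at 40 nM, range 10 nM to 200 nM.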

Compound 3, half-maximal inhibitory concentration: 8 nM
Estimate against measurement, compound 3: 5.0-fold (0.70 log units) above; measured number below the stated range.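

Among these compounds, this is the first change read at a single place: on the saturated chain carbon, two bonds along the chain from an aromatic carbon, (2-aminoethyl)sulfanyl in place of methyl gives an at least 12-fold lower number from compound 1 to compound 3 (1.09 log units; beyond the scatter) in this assay. The core of compound 1 therefore accepts this longer chain with a clear gain. Compound 1 is only a limit, so the step has a floor and no exact size: the limit of > 100 nM in this assay, at which 1 of the 3 values shown sits.

Still open, as far as these compounds go, is whether the amine or the sulfur carries the gain; an all-carbon chain ending in an amine and the same sulfur chain ending in a hydroxyl would separate them. From the compounds shown here alone, the effect of a longer chain also remains open.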